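Aryl tail variation on the oxazole ketone series

The source may hold more compounds than are shown below. What is called first, only, known or untested is meant among the compounds shown, and "the series" means these compounds.

Going by the values given here, compound 2 `Nc1ccc(CCCCCCC(=O)c2ncc(-c3ccccn3)o2)cc1` carries a 4-aminophenyl at the chain end; in an assay for inhibition of Fatty-acid amide hydrolase 1 (Rattus norvegicus) (a lower number here means a stronger inhibitor, a higher number a weaker inhibitor), compound 2 gives 3 nM, the only numerical value in the set. Compound 1 `O=C(CCCCCCc1ccccc1C(=O)O)c1ncc(-c2ccccn2)o1` bears a 2-carboxyphenyl at the same place. In this assay compound 1 reaches only a limit, > 600 nM, and not a number. Among the compounds with values here, the one measured step, an at least 200-fold lower number from compound 1 to compound 2 (2.30 log units; beyond the scatter), is large, and its size rests on the limit of > 600 nM in this assay, at which 1 of the 2 values shown sits, rather than on two determined values.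

Compound 3 `CSc1ccccc1CCCCCCC(=O)c1ncc(-c2ccccn2)o1` is the next member: 2-(methylsulfanyl)phenyl in place of 4-aminophenyl on a saturated chain carbon, six bonds along the chain from a carbonyl carbon. This change bears only indirectly on the measured step, since compound 1 and compound 3 share a 2-substituted phenyl but differ in the substituent itself. A 4-aminophenyl gave the strong value of compound 2, so replacing it is expected to weaken binding, though without a carboxy group the loss need not reach the limit seen for compound 1. The estimated step is a 10-fold higher number from compound 2 to compound 3 (1.00 log units; beyond the scatter), and compound 3 is expected to give about 30 nM, with a range from 5 nM to 250 nM.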

Compound 3, inhibition constant: 3.3 nM
Compound 3: the middle estimate sits 9.1-fold (0.96 log units) above what was measured; the measured number lies below the stated range.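

In this assay, the exchange at the chain end gives a 1.1-fold higher number from compound 2 to compound 3 (0.04 log units; within the scatter), so compound 2 and compound 3 cannot be told apart. At this position, the strong binding seen with the 4-aminophenyl therefore does not require that group, and a 2-(methylsulfanyl)phenyl with 0 hydrogen-bond donors serves equally well. Compound 1 and compound 3 now form a pair differing in one place, methylsulfanyl in place of carboxy on an aromatic carbon, which gives an at least 180-fold lower number from compound 1 to compound 3 (2.25 log units; beyond the scatter) and ties the weak result of compound 1 to the carboxy group rather than to a substituted phenyl as such, although the size of this step is only bounded: the limit of > 600 nM in this assay, at which 1 of the 3 values shown sits.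

Still open, as far as these compounds go, is whether an unsubstituted phenyl would match compound 2 and compound 3, which would show whether the amine and methylsulfanyl groups contribute anything at this position. From the compounds shown here alone, it is equally open whether a 4-carboxyphenyl would behave like the 2-carboxyphenyl of compound 1, and whether the equivalence of compound 2 and compound 3 would hold on a longer chain.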